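A tert-butyl nitrone on two triazole cores

A few compounds are considered here, and "the series" means these few. Any claim that something is new, unique, unknown or untested is made for them only; others in the source may bear on it.

The study covers three measured compounds and one still to be measured, all tested in a functional assay on A549 cells (Homo sapiens) for inhibition, read by MTT assay, with a stated time of 24 h; on this read-out higher numbers stand for weaker inhibition and lower numbers for stronger inhibition. Compound 1 `[O-]/[N+](=C\c1cn(-c2ccccc2)nn1)Cc1ccccc1` carries a benzyl group on the double-bonded nitrogen. In this assay compound 1 returns only a limit of the assay, > 100000 nM. Compound 2 `CCCCCCCCn1cc(/C=[N+](\[O-])Cc2ccccc2)nn1` keeps the benzyl group but rests on a different core; the difference between the two cores is not broken down here. In this assay compound 2 also returns a limit rather than a number, > 100000 nM. Compound 3 `CC(C)(C)/[N+]([O-])=C/c1cn(-c2ccccc2)nn1` differs from compound 1 by tert-butyl in place of benzyl on a double-bonded nitrogen. In this assay compound 3 gives 17400 nM. That change produced an at least 5.7-fold lower number from compound 1 to compound 3 (0.75 log units; beyond the scatter).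

Compound 4 `CCCCCCCCn1cc(/C=[N+](\[O-])C(C)(C)C)nn1` stands to compound 2 as compound 3 stands to compound 1, differing by tert-butyl in place of benzyl on a double-bonded nitrogen. The place is described in identical words for both pairs, so it is the same change, made twice among these compounds. The starting point of the second step is a bound, not a number: compound 2 sits at the limit of > 100000 nM in this assay, at which 2 of the 3 values shown sit. Any expectation for compound 4 therefore rests on the one measured step, from compound 1 to compound 3, an at least 5.7-fold lower number from compound 1 to compound 3 (0.75 log units; beyond the scatter), and on the untested assumption that the second core behaves alike. On that basis compound 4 is expected to show an at least 4.0-fold lower number from compound 2 to compound 4 (0.60 log units; beyond the scatter). Compound 4 is thus estimated at 25000 nM, with a range from 8000 nM to 100000 nM, and with a real chance that it too returns only a limit.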

Compound 4, half-maximal inhibitory concentration: 31300 nM
Compound 4: the middle estimate sits 1.3-fold (0.10 log units) below what was measured; measured number inside the range.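

In this assay, the change from benzyl to tert-butyl on the double-bonded nitrogen, already seen on the core of compound 1, also gave a lower number on the second core, with an at least 3.1-fold lower number from compound 2 to compound 4 (0.50 log units; beyond the scatter). From the compounds shown here alone, this step, like the earlier one, starts from a limit rather than a number, so its true size remains unknown: the limit of > 100000 nM in this assay, at which 2 of the 4 values shown sit. The two steps therefore show that the change runs in the same direction on both cores, but not that it has the same size, and two cores cannot establish that it would carry over to any further core: the same change on two cores in this assay, an at least 5.7-fold lower number (0.75 log units; beyond the scatter) from compound 1 to compound 3 and an at least 3.1-fold lower number (0.50 log units; beyond the scatter) from compound 2 to compound 4; the limit leaves it open whether they differ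

The compounds shown have only benzyl and tert-butyl on the double-bonded nitrogen, so they leave open whether isopropyl, cyclohexyl or a longer branched chain there would give a measurable number in this assay or only a limit. They also leave open how the series would read with an amine or a carboxylic acid attached to the core, and whether the same change would still lower the number on a core carrying either group.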